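Removing the amine methyl from a weakly binding core

The source may report more compounds than this note shows. Statements on the series, on what has been measured and on what is new or still open speak of the compounds shown alone.

The three measured compounds were tested in an assay on HEK293 cells for displacement of a labelled ligand from Neuronal acetylcholine receptor; alpha4/beta4 (Rattus norvegicus), with a stated time of 4 h; on this read-out higher numbers stand for weaker inhibition and lower numbers for stronger inhibition:

compound 1, `CCO[C@H]1CC=C2CCN(C)[C@H]2C1`, gives > 300000 nM in this assay.
compound 2, `CO[C@H]1CC=C2CCN[C@H]2C1`, gives > 300000 nM in this assay.
compound 3, `CN1CCC2=CC[C@H](O)C[C@@H]21`, gives > 300000 nM in this assay.

Each of these values is a limit of this assay, not a number: the binding of compound 3 was too weak to be measured, and the same holds for compound 1 and compound 2. Among the compounds with values here, because of the limit of > 300000 nM in this assay, at which 3 of the 3 values shown sit, the only step that joins two measured compounds, a step that the two limits leave unreadable from compound 1 to compound 3, cannot be read, so its size is unknown.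

Compound 4, `O[C@H]1CC=C2CCN[C@H]2C1`, has not yet been measured. It differs from compound 3 by hydrogen in place of methyl on an amine nitrogen in a ring. Within the data shown here, no measured pair shows this change on its own, so nothing shows whether it helps or hurts. Compound 2, which also carries hydrogen on the amine nitrogen, sits at the limit, as does compound 3. Compound 4 is therefore expected to remain at or near the limit in this assay, with an estimated step of a number no higher from compound 3 to compound 4 (the limit leaves the size open), giving an estimate of 300000 nM, ranging from 100000 nM to 1000000 nM.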

Compound 4, inhibition constant: > 300000 nM
Compound 4: only a limit was reported; the forecaster's own chance of this, stated with the estimate: 85%; the middle value lies on the limit itself.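

Compound 4 also gives a limit, not a number, so the steps to it from compound 2 and compound 3 cannot be read, because all the values share one limit: the limit of > 300000 nM in this assay, at which 4 of the 4 values shown sit.

The compounds shown leave open how large any of these steps is in this assay, and whether any change to the shared core gives binding strong enough to measure.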